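A few compounds are considered here, and "the series" means these few. Any claim that something is new, unique, unknown or untested is made for them only; others in the source may bear on it.

Compound 1 `CC(C(=O)NCc1ccc(C(F)(F)F)nc1NC1CCCCC1)c1ccc(NS(C)(=O)=O)c(F)c1` and compound 2 `CC(C(=O)NCc1ccc(C(F)(F)F)nc1N1CC=CCC1)c1ccc(NS(C)(=O)=O)c(F)c1` share a core and differ only in the ring attached to one aromatic carbon. In a functional assay on CHO-K1 cells for antagonist activity at transient receptor potential cation channel subfamily V member 1 (Homo sapiens), read by FLIPR (on this read-out lower numbers stand for stronger inhibition and higher numbers for weaker inhibition), compound 1 gives 20.4 nM. In this assay compound 2 gives 0.3 nM, the lowest of the two numbers, reached by a 68-fold lower number from compound 1 to compound 2 (1.83 log units; beyond the scatter). Compound 3 `CC(C(=O)NCc1ccc(C(F)(F)F)nc1N1CCC(c2ccccc2)CC1)c1ccc(NS(C)(=O)=O)c(F)c1` carries a group of 12 heavy atoms (11 carbon, 1 nitrogen; one six-membered non-aromatic ring with 1 hetero atom, one six-membered aromatic ring of carbon only) in place of a group of 6 heavy atoms (5 carbon, 1 nitrogen; one six-membered non-aromatic ring with 1 hetero atom), on an aromatic carbon. For the measured compounds named here, that single measured step shows how strongly this ring governs the number, yet no measured compound carries a 4-phenylpiperidin-1-yl group, so the direction remains uncertain. A moderate loss is expected, with a 10-fold higher number from compound 2 to compound 3 (1.00 log units; beyond the scatter). For compound 3 the estimate in this assay is 3 nM, within 0.3 nM to 30 nM.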

Compound 3, inhibition constant: 0.6 nM
Compound 3: the middle estimate sits 5.0-fold (0.70 log units) above what was measured; low and high end bracket the measured number.
By their numbers in this assay, from the lowest: compounds 2 and 3 (each within the scatter of the next); then compound 1.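

In this assay, the aromatic carbon next to the ring nitrogen accepts the larger 4-phenylpiperidin-1-yl group, with a 2.0-fold higher number from compound 2 to compound 3 (0.30 log units; within the scatter), so adding a phenyl-bearing ring here leaves the number within normal scatter. The separation from the cyclohexylamino group remains, with a 34-fold lower number from compound 1 to compound 3 (1.53 log units; beyond the scatter), and among these compounds both groups joined through their ring nitrogen give lower numbers than the group joined through an amino nitrogen. No available evidence explains this difference. Going by these compounds, it remains open whether a morpholin-4-yl group, or a 4-phenylpiperidin-1-yl group with a carboxylic acid on its phenyl ring, would keep the number this low.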